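A few compounds are considered here, and "the series" means these few. Any claim that something is new, unique, unknown or untested is made for them only; others in the source may bear on it.

Working notes on the series, read in a functional assay (aorta) with Rattus norvegicus as the target; on this read-out lower numbers stand for an effect already at smaller amounts and higher numbers for an effect only at larger amounts of compound. Going by the values given here, compound 1 (`N#Cc1ccc2c(c1)[C@@H](N1CCCCC1=O)[C@H](O)C(CF)(CF)O2`) gives 8.91 nM, and compound 2 (`O=C1CCCCN1[C@@H]1c2cc([N+](=O)[O-])ccc2OC(CF)(CF)[C@H]1O`) gives 2.75 nM, the lowest of the two numbers available so far. Among the compounds with values here, the single measured step, a 3.2-fold lower number from compound 1 to compound 2 (0.51 log units; beyond the scatter), is nitro in place of cyano on an aromatic carbon.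

Compound 3 (`O=C1CCCCN1[C@@H]1c2cc(C(F)(F)C(F)(F)F)ccc2OC(CF)(CF)[C@H]1O`) keeps the shared core of compound 2 and changes that same group: 1,1,2,2,2-pentafluoroethyl in place of nitro on an aromatic carbon. In words, this is 1,1,2,2,2-pentafluoroethyl in place of nitro on an aromatic carbon. Within the data shown here, no measured compound carries 1,1,2,2,2-pentafluoroethyl, so only the one step bears on this change, and only as a rough guide to how far a change of this group can move the number. Among the measured compounds shown here, with a 3.2-fold lower number from compound 1 to compound 2 (0.51 log units; beyond the scatter) as the sole reference and compound 2 at 2.75 nM as the low end of the series, a step no larger than that one is expected in this assay, towards a higher number and possibly within the scatter. The expected step is a 1.8-fold higher number from compound 2 to compound 3 (0.26 log units; within the scatter). For compound 3 the estimated value is 5 nM, with an expected range of 1.5 nM to 16 nM.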

Compound 3, half-maximal effective concentration: 3.89 nM
Estimate against measurement, compound 3: 1.3-fold (0.11 log units) above, within the range that was stated.
By their numbers in this assay, from the lowest: compounds 2 and 3 (each within the scatter of the next); then compound 1.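

At this position, on an aromatic carbon meta to a fused ring and para to a fused ring, the change in this assay is a 1.4-fold higher number from compound 2 to compound 3 (0.15 log units; within the scatter), so a group of carbon and fluorine with 0 hydrogen-bond acceptors cannot be told apart from nitro, which has 2. The earlier pair showed only that nitro and cyano differ; the same position now also accepts the larger 1,1,2,2,2-pentafluoroethyl, with 7 heavy atoms against 3 for nitro, and the comparison with cyano reads a 2.3-fold lower number from compound 1 to compound 3 (0.36 log units; beyond the scatter), so two groups of quite different atom make-up both lie beyond the scatter from the cyano compound. Nothing measured on these compounds accounts for either step, and no supporting data bear on them.

Open, going by these compounds, is how an amine, a carboxylic acid or a single chlorine atom on this same aromatic carbon would read, and whether a longer perfluoroalkyl chain would keep the number at this level. All three compounds also share the rest of the core, so the series says nothing yet about how these steps hold once another part of it changes.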